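This account rests on a few compounds, and the source may have more. Where it says the series, first, only, none or still open, it means among the compounds named here.

Compound 1 `C=CC1=C(C(=O)NCc2ccc(Cl)cc2)C(c2ccc(OC)cc2)OC1` gave in a functional assay on QGY7701 cells (Homo sapiens) for cytotoxicity, read by MTT assay, with a stated time of 24 h (on this read-out higher numbers stand for weaker inhibition and lower numbers for stronger inhibition), only the limit > 100000 nM.
Compound 2 `C=CC1=C(C(=O)NCc2ccc(C)cc2)C(c2ccc(OC)c(OC)c2)OC1` gave in this assay a half-maximal inhibitory concentration of 69100 nM.

Compound 2 therefore holds the only numerical result among these two; the result for compound 1 is a limit of the assay rather than a number (the limit of > 100000 nM in this assay, at which 1 of the 2 values shown sits). Compound 3 `C=CC1=C(C(=O)NCc2ccc(Cl)cc2)C(c2ccc(OC)c(OC)c2)OC1` has not yet been tested in this assay. It differs from compound 2 by chloro in place of methyl on an aromatic carbon, para to a large group. Among the measured compounds shown here, no measured pair shows this exact exchange on the same core, so neither the direction nor the size of the step can be read from what has been measured. The expected step of a 1.2-fold higher number from compound 2 to compound 3 (0.06 log units; within the scatter) is not expected to exceed the usual scatter, with a real chance that only a limit is returned. The estimate for compound 3 in this assay is 80000 nM, between 30000 nM and 250000 nM.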

Compound 3, half-maximal inhibitory concentration: > 100000 nM
Compound 3: no number, only a limit; the forecaster's own chance of this, stated with the estimate: 40%; middle value at least 1.2-fold (0.09 log units) away from the limit.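

Among the compounds shown here, the exchange of 4-methylbenzyl for 4-chlorobenzyl gives the first readable step at this position in this assay, an at least 1.4-fold higher number from compound 2 to compound 3 (0.16 log units; that floor lies within the scatter), so only a floor for the change is known, and that floor does not clear the scatter. For the compounds shown here, compound 3 returns a limit and not a number, which places both compounds carrying 4-chlorobenzyl at the limit, while the only number belongs to the 4-methylbenzyl compound 2: the limit of > 100000 nM in this assay, at which 2 of the 3 values shown sit. The step from compound 1 to compound 3, methoxy in place of hydrogen on an aromatic carbon, cannot be read, as both results are limits.

The compounds shown leave open whether the true change from methyl to chloro exceeds the scatter. They also leave open what an amine or a carboxylic acid on this aromatic carbon would give.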